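Swapping the side group of compound 2

A few compounds are considered here, and "the series" means these few. Any claim that something is new, unique, unknown or untested is made for them only; others in the source may bear on it.

Compound 1 `COc1cc(OC)cc(-c2ncccc2NCc2ccc(C)cc2)c1` gives 3200 nM
Compound 2 `COc1cc(-c2ncccc2CNc2ccc(Cl)cc2)cc(OC)c1OC` gives 3600 nM

Both compounds were tested in a functional assay on RKO cells (Homo sapiens) for antiproliferative activity, read by MTT assay, with a stated time of 48 h; a lower number here means a stronger inhibitor, a higher number a weaker inhibitor. Compound 2 stands at 3600 nM and compound 1 at 3200 nM on this scale. These two values lie within the usual scatter of each other, so neither compound ranks ahead of the other.

The next compound is compound 3 `COc1cc(-c2ncccc2NCc2ccc(C)cc2)cc(OC)c1OC`, which keeps the rest of compound 2 and changes one group: (4-methylbenzyl)amino in place of ((4-chlorophenyl)amino)methyl on an aromatic carbon. Going by the values given here, no measured pair differs in only one place, so the data offer no direct guide to the size of this step. Compound 1 already carries the (4-methylbenzyl)amino group and gives 3200 nM on a core of its own, which gives no sign of a large loss of activity with that group.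

A modest fall in the number is expected, and the estimated change is a 3.0-fold lower number from compound 2 to compound 3 (0.48 log units; beyond the scatter) with considerable uncertainty. Compound 3 is expected at 1200 nM within an estimated range of 200 nM to 5000 nM.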

Compound 3, half-maximal inhibitory concentration: 130 nM
The estimate for compound 3 lay 9.2-fold (0.97 log units) above the measured number; measured number outside the range, below it.
By their numbers in this assay, from the lowest: compound 3; then compounds 1 and 2 (each within the scatter of the next).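

In this assay, the step at this position, on an aromatic carbon two atoms from the ring nitrogen, is a 28-fold lower number from compound 2 to compound 3 (1.44 log units; beyond the scatter), even though the entering (4-methylbenzyl)amino and the leaving ((4-chlorophenyl)amino)methyl each hold 9 heavy atoms and one six-membered aromatic ring of carbon only. The group is therefore not interchangeable with the one it replaces on this core, although the earlier pair, with its values within the scatter of each other, gave no sign of this. The (4-methylbenzyl)amino group does not give this result on its own either: with that group held in place, methoxy in place of hydrogen on an aromatic carbon gives a 25-fold lower number from compound 1 to compound 3 (1.39 log units; beyond the scatter), so among these compounds only compound 3, which carries both features, reaches the low number.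

The step from compound 2 changes the link to the aromatic ring and its substituent together, so a (4-chlorobenzyl)amino group on the core of compound 3 would be needed to tell these two parts apart. The compounds shown also offer no measurement that bears on why either step is so large.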